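Methoxycarbonyl to carboxy: the step to compound 4

A few compounds are considered here, and "the series" means these few. Any claim that something is new, unique, unknown or untested is made for them only; others in the source may bear on it.

Measured compounds, with values from a functional assay on L1210 cells (Mus musculus); on this read-out lower numbers stand for stronger inhibition and higher numbers for weaker inhibition
- compound 1 `NC(=O)c1nn([C@@H]2O[C@H](CO)[C@@H](O)[C@H]2O)cc1I` gives > 300000 nM (a limit)
- compound 2 `COC(=O)c1nn([C@@H]2O[C@H](CO)[C@@H](O)[C@H]2O)cc1I` gives 2400 nM
- compound 3 `C#Cc1cn([C@@H]2O[C@H](CO)[C@@H](O)[C@H]2O)nc1C(N)=O` gives > 300000 nM (a limit)

In this assay, among the compounds with values here, compound 2 gives 2400 nM and holds the only readable number of the set. The other two values stand at the limit of > 300000 nM in this assay, at which 2 of the 3 values shown sit, and are limits, not numbers.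

Compound 4 `O=C(O)c1nn([C@@H]2O[C@H](CO)[C@@H](O)[C@H]2O)cc1I` has yet to be measured. Its difference from compound 2 is hydrogen in place of methyl on an oxygen next to a carbonyl group, which reads as methoxy to hydroxy.

The measured step that bears on this is an at least 120-fold lower number from compound 1 to compound 2 (2.09 log units; beyond the scatter) (methoxy in place of amino on a carbonyl carbon), and it was large. The other measured step, a step that the two limits leave unreadable from compound 1 to compound 3 with ethynyl in place of iodo on an aromatic carbon, gives no guide to size. Compound 4 also loses the methoxy, and because of an at least 120-fold lower number from compound 1 to compound 2 (2.09 log units; beyond the scatter) the reason for expecting a change rests on compound 1 and that step read in reverse. A large move toward weaker inhibition is therefore expected in this assay rather than none.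

The expected change is a 42-fold higher number from compound 2 to compound 4 (1.62 log units; beyond the scatter) in that direction. The estimate for compound 4 is 100000 nM with an expected range from 15000 nM to 300000 nM and the result may prove to be only a limit.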

Compound 4, half-maximal inhibitory concentration: > 300000 nM
Compound 4 ended at the assay's limit (the forecaster's own chance of this, stated with the estimate: 55%); at least 3.0-fold (0.47 log units) between middle value and limit.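

In this assay, the methoxycarbonyl of compound 2 does not survive the smallest cut made to it: hydrogen in place of methyl on an oxygen next to a carbonyl group gives an at least 120-fold higher number from compound 2 to compound 4 (2.09 log units; beyond the scatter). Compound 4 gives > 300000 nM, which is a limit of the assay and not a number. The earlier compounds had shown only that amino on the carbonyl carbon does not replace methoxy, whereas this result shows that the single methyl on that oxygen separates the one readable value from a limit; the step between compound 1 and compound 4 cannot be read, as both of its ends are limits, so amino and hydroxy on the carbonyl carbon cannot be ranked.

The compounds shown still offer little to compare: the limit of > 300000 nM in this assay, at which 3 of the 4 values shown sit. On these data alone, whether ethoxy or a longer chain on that oxygen would keep a readable value stays open, as does the effect of ethynyl in place of iodo on an aromatic carbon when methoxycarbonyl is present.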